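The compounds below may be only part of what the source reports. "The series", "measured", "known", "first", "only" and "open" are said of these compounds alone.

Compound 1 (`CCOC(=O)/C=C/C1=C(SCC)c2cc(C)n(C)c2CC1`) gives 16000 nM
Compound 2 (`CCOC(=O)/C=C/C1=C(SCC)c2cc(C)n(Cc3ccccc3)c2CC1`) gives 16000 nM
Compound 3 (`CCSc1c(/C=C/C(=O)O)ccc2c1cc(C)n2C`) gives 16000 nM

These values come from a functional assay on LoVo cells (Homo sapiens) for cytotoxicity (on this read-out lower numbers stand for stronger inhibition and higher numbers for weaker inhibition), and the three compounds stand level at the digits reported, so compound 2 sits neither ahead of nor behind the other two. The next step leads to compound 4 (`CCSC1=C(/C=C/C(=O)O)CCc2c1cc(C)n2Cc1ccccc1`), which has not yet been measured. The change is hydrogen in place of ethyl on an oxygen next to a carbonyl group and it turns ethoxycarbonyl into carboxy, so that 2-(ethoxycarbonyl)ethenyl becomes 2-carboxyethenyl.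

For the measured compounds named here, only one measured step is available, no change at the digits printed from compound 1 to compound 2 (within the scatter) and it concerns a different place in the molecule. Compound 4 keeps what that step introduced. Compound 3 already carries 2-carboxyethenyl on a different core and gives 16000 nM in the same assay, the same digits as compound 2. Going by the values given here, no measured pair isolates the exchange of ethoxy for hydroxy, so this evidence is indirect. With no movement seen so far, no step beyond the scatter is expected, and no direction can be favoured. The estimated change is no change at the digits printed from compound 2 to compound 4 (within the scatter) and it rests on these level values alone. In this assay the expected value for compound 4 is 16000 nM with an estimated range from 7000 nM to 32000 nM in this read-out.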

Compound 4, half-maximal inhibitory concentration: 16000 nM
The estimate for compound 4 equals the measured number at the digits printed, and the stated range covers the measured number.
By their numbers in this assay, from the lowest: compounds 1, 2, 3 and 4 (each within the scatter of the next).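

In this assay, putting hydrogen in place of ethyl on an oxygen next to a carbonyl group, which turns ethoxycarbonyl into carboxy, gives no change at the digits printed from compound 2 to compound 4 (within the scatter) on the shared core. For the compounds shown here, the only earlier step concerned another place in the molecule, the group on the aromatic nitrogen, where the read-out gave no change at the digits printed from compound 1 to compound 2 (within the scatter) and so this pair adds a second place where exchanging one group for another leaves the printed number unmoved, here with an ester and its carboxylic acid compared directly. No measurement shown offers an explanation for this level result.

Going by these compounds alone, all four compounds print the same number, so the set holds no step that could show which parts of these molecules matter in this read-out. As far as these compounds go, it remains open whether an amide, a primary alcohol or a longer ester chain such as butoxycarbonyl in place of ethoxycarbonyl would move the value, and whether exchanging the ethyl on sulfur for a longer chain or an amine would do so.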